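The source may report more compounds than this note shows. Statements on the series, on what has been measured and on what is new or still open speak of the compounds shown alone.

Measured so far:
compound 1 `Cc1nc(C)c([C@H](OC(C)(C)C)C(=O)O)c(N2CCC(C)(C)CC2)c1-c1ccc(OCCc2ccc(Cl)cc2)cc1` — >= 33500 nM
compound 2 `Cc1nc(C)c([C@H](OC(C)(C)C)C(=O)O)c(N2CCC(C)(C)CC2)c1-c1ccc(OC2CCCC2c2ccc(F)cc2)cc1` — >= 32000 nM; >= 32000 nM (2 entries)

In a toxicity assay on MT2 cells (Homo sapiens) for cytotoxicity, read by XTT assay, with a stated time of 4 days (a lower number here means that less compound is tolerated, a higher number that more compound is tolerated), compound 1 gives >= 33500 nM, which is a limit of the assay and not a number. Compound 1 therefore stands at the limit, as the limit of >= 33500 nM in this assay, at which 1 of the 2 values shown sits, shows. Compound 3 `Cc1nc(C)c([C@H](OC(C)(C)C)C(=O)O)c(N2CCC(C)(C)CC2)c1-c1ccc(OCCc2ccccn2)cc1` is not yet measured in this assay. It differs from compound 1 in one place: pyridin-2-yl in place of 4-chlorophenyl on a saturated chain carbon, two bonds along the chain from an oxygen on an aromatic ring. Going by the values given here, no measured pair shows the effect of this change. With both measured compounds at the limit, no step beyond the scatter is expected; the step from compound 1 to compound 3 is estimated as a step that the limit leaves unreadable from compound 1 to compound 3. Compound 3 is estimated at 35000 nM, within 15000 nM to 80000 nM.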

Compound 3, half-maximal cytotoxic concentration: >= 25000 nM
Compound 3: a limit, no number (the forecaster's own chance of this, stated with the estimate: 85%); the middle value is on the limit's open side.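

In this assay, going by these compounds alone, compound 1 and compound 3 both give limits of the assay and not numbers, so no step between them can be read. The compounds shown leave open whether pyridin-2-yl in place of 4-chlorophenyl changes the half-maximal cytotoxic concentration at all.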